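Removing one fluoro from a difluorobenzyl group: expected solubility

The source may hold more compounds than are shown below. What is called first, only, known or untested is meant among the compounds shown, and "the series" means these compounds.

Compound 1 `O=c1nc(N2CCC3(CCN(Cc4ccccc4)C3)CC2)sc2c([N+](=O)[O-])cc(C(F)(F)F)cc12`, compound 3 `O=c1nc(N2CCC3(CCN(Cc4ccc(F)cc4)C3)CC2)sc2c([N+](=O)[O-])cc(C(F)(F)F)cc12` and compound 2 `O=c1nc(N2CCC3(CCN(Cc4cc(F)cc(F)c4)CC3)CC2)sc2c([N+](=O)[O-])cc(C(F)(F)F)cc12` were measured in a physicochemical assay for solubility, read by HPLC, with a stated time of 12 h, at pH 2; on this read-out higher numbers stand for higher solubility and lower numbers for lower solubility. Under these conditions compound 1 gives 1.56 ug/mL, compound 3 gives 1.12 ug/mL and compound 2 gives 0.67 ug/mL. Compound 1 differs from compound 3 by hydrogen in place of fluoro on an aromatic carbon, and that change brought a 1.4-fold higher number from compound 3 to compound 1 (0.14 log units; within the scatter). The difference between the cores of compound 2 and compound 3 is not broken down here. Compound 4 `O=c1nc(N2CCC3(CCN(Cc4cccc(F)c4)CC3)CC2)sc2c([N+](=O)[O-])cc(C(F)(F)F)cc12` differs from compound 2 by hydrogen in place of fluoro on an aromatic carbon, the same kind of change, although the place is now meta to a fluoro group and meta to a large group rather than para to a large group. Because the earlier step of a 1.4-fold higher number from compound 3 to compound 1 (0.14 log units; within the scatter) stayed small, the step expected for compound 4 is a 1.3-fold higher number from compound 2 to compound 4 (0.13 log units; within the scatter). Compound 4 is therefore estimated at 0.9 ug/mL, with a likely range from 0.5 ug/mL to 1.6 ug/mL.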

Compound 4, solubility: 1.13 ug/mL
Compound 4: the middle estimate sits 1.3-fold (0.10 log units) below what was measured; low and high end bracket the measured number.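

In this assay hydrogen in place of fluoro on an aromatic carbon gave a 1.7-fold higher number from compound 2 to compound 4 (0.23 log units; within the scatter) on one core and a 1.4-fold higher number from compound 3 to compound 1 (0.14 log units; within the scatter) on the other, so the two steps point the same way and both lie within the scatter. This shows that the change carried from one core to the other without a step beyond the scatter, but two such pairs, which also differ in the place of the change, do not establish a real effect on either core. Nothing available bears on why the steps came out this way.

The compounds shown leave open what a methoxy group or an amine in place of the fluoro of the 3-fluorobenzyl group would give. They also leave open whether the same step would hold on any further core.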